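Swapping 2-fluorophenyl for thiophen-2-yl in compound 1

The compounds below may be only part of what the source reports. "The series", "measured", "known", "first", "only" and "open" are said of these compounds alone.

In a functional assay on microsomes for inhibition, with a stated time of 1 h (on this read-out higher numbers stand for weaker inhibition and lower numbers for stronger inhibition), compound 1 `CCOC(=O)c1cnn(-c2nc(-c3ccccc3F)c(C#N)c(=O)n2C)c1N` gives 94 ug/mL and compound 2 `CSc1nc(-c2cccs2)c(C#N)c(=O)n1C` gives 83 ug/mL, two values within the usual scatter of each other. Compound 3 `CCOC(=O)c1cnn(-c2nc(-c3cccs3)c(C#N)c(=O)n2C)c1N` keeps the core of compound 1 but carries thiophen-2-yl in place of 2-fluorophenyl on an aromatic carbon. For the measured compounds named here, no measured pair shows this swap alone, though compound 2 also carries thiophen-2-yl. In this assay no step beyond the scatter is expected, and the estimated move a 1.1-fold lower number from compound 1 to compound 3 (0.04 log units; within the scatter) is small. Compound 3 is estimated at 85 ug/mL, with an expected range from 40 ug/mL to 170 ug/mL.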

Compound 3, half-maximal inhibitory concentration: 97 ug/mL
Estimate against measurement, compound 3: 1.1-fold (0.06 log units) below, within the range that was stated.
By their numbers in this assay, from the lowest: compounds 2, 1 and 3 (each within the scatter of the next).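

In this assay, for the compounds shown here, the swap of 2-fluorophenyl for thiophen-2-yl, on the aromatic carbon ortho to a cyano group, gives a 1.0-fold higher number from compound 1 to compound 3 (0.01 log units; within the scatter) and is the first direct reading of this change. At this position, with the rest of compound 1 kept, one aromatic ring stands in for the other without a step beyond the scatter. No measurement here offers an explanation for this result.

Still open, as far as these compounds go, is what happens when an amine, a carboxylic acid or a longer chain sits at this position instead of an aromatic ring. The three compounds also leave open whether any group here can shift the number beyond the scatter.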